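A Cyclohexyl Ring on the Alkyne of Compound 2

A few compounds are considered here, and "the series" means these few. Any claim that something is new, unique, unknown or untested is made for them only; others in the source may bear on it.

Measured in an assay on HEK293 cells for displacement of a labelled ligand from adenosine receptor A3 (Mus musculus), read by scintillation counting, with a stated time of 60 min; on this read-out higher numbers stand for weaker inhibition and lower numbers for stronger inhibition:
- compound 1, `CNC(=O)[C@@]12C[C@@H]1[C@@H](n1cnc3c(NC)nc(C#Cc4ccc(F)c(F)c4)nc31)[C@H](O)[C@@H]2O`: 86 nM
- compound 2, `CNC(=O)[C@@]12C[C@@H]1[C@@H](n1cnc3c(NC)nc(C#Cc4cnn(C)c4)nc31)[C@H](O)[C@@H]2O`: 126 nM

Going by the values given here, only two numbers are known, and compound 2 sits at a distance from compound 1 of a 1.5-fold higher number from compound 1 to compound 2 (0.17 log units; within the scatter), so the two cannot be told apart. Compound 3, `CNC(=O)[C@@]12C[C@@H]1[C@@H](n1cnc3c(NC)nc(C#CC4CCCCC4)nc31)[C@H](O)[C@@H]2O`, has not been measured in this assay. It differs from compound 2 in one place: cyclohexyl in place of 1-methyl-1H-pyrazol-4-yl on a triple-bonded carbon. Among the compounds with values here, the single measured step, from compound 1 to compound 2, exchanged one aromatic ring for another on the same triple-bonded carbon and stayed within the scatter; the present change instead brings in a saturated ring, so that step bears on it only loosely. Within the data shown here, no measured step shows this kind of exchange. On that basis compound 3 is expected to come out near compound 2, with an estimated step of a 1.3-fold higher number from compound 2 to compound 3 (0.10 log units; within the scatter) in this assay, and the estimate for compound 3 is 160 nM, within a range from 50 nM to 500 nM.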

Compound 3, inhibition constant: 40.9 nM
The estimate for compound 3 lay 3.9-fold (0.59 log units) above the measured number, outside the stated range (below it).
By their numbers in this assay, from the lowest: compound 3; then compounds 1 and 2 (each within the scatter of the next).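

In this assay, going by these compounds alone, cyclohexyl on the triple-bonded carbon gives a 3.1-fold lower number from compound 2 to compound 3 (0.49 log units; beyond the scatter) and also a 2.1-fold lower number from compound 1 to compound 3 (0.32 log units; beyond the scatter) at this position, the first steps here that lie beyond the scatter. The exchange of one aromatic ring for another had left compounds 1 and 2 indistinguishable, whereas this result shows that the group on the triple-bonded carbon can shift the number, if only modestly, and that an aromatic ring is not required there. Nothing measured on these compounds accounts for the change.

From the compounds shown here alone, what remains open is whether any ring is needed at all, since a straight hexyl chain on the same triple-bonded carbon would test that. Also open, going by these compounds, is how an amine would fare there, for example in a piperidin-4-yl ring of similar size to cyclohexyl.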